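A few compounds are considered here, and "the series" means these few. Any claim that something is new, unique, unknown or untested is made for them only; others in the source may bear on it.

Measured compounds:
compound 1 `CCOC(=O)C1=Cc2ccccc2OC1(OCc1cn(CC(=O)Nc2cccc(Cl)c2)nn1)C(F)(F)F` gives 12300 nM in a functional assay on HeLa cells (Homo sapiens) for inhibition, read by MTT assay, with a stated time of 24 h; on this read-out higher numbers stand for weaker inhibition and lower numbers for stronger inhibition;
compound 2 `CCOC(=O)C1=Cc2ccccc2OC1(OCc1cn(CC(=O)Nc2ccc(C)cc2)nn1)C(F)(F)F` gives 67400 nM in this assay.

Of these two numbers, compound 1 holds the lower one, and the step of a 5.5-fold higher number from compound 1 to compound 2 (0.74 log units; beyond the scatter) shows that swapping the ring on the amide-type nitrogen matters here. Compound 3 `CCOC(=O)C1=Cc2ccccc2OC1(OCc1cn(CC(=O)Nc2ccccc2Br)nn1)C(F)(F)F` differs from compound 1 by 2-bromophenyl in place of 3-chlorophenyl on an amide-type nitrogen. For the measured compounds named here, only the step from compound 1 to compound 2 bears on this change, and it weakened inhibition, so a modest rise in the number for compound 3 is expected, though a result within the scatter would not surprise. Compound 3 is therefore estimated at 22000 nM, with a range from 8000 nM to 60000 nM, meaning an expected step of a 1.8-fold higher number from compound 1 to compound 3 (0.25 log units; within the scatter).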

Compound 3, half-maximal inhibitory concentration: > 150000 nM
Compound 3 was reported as a limit; the forecaster's own chance of this, stated with the estimate: 15%; at least 6.8-fold (0.83 log units) between middle value and limit.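

Changing the ring on the amide-type nitrogen can cost far more than the first pair showed, with an at least 12-fold higher number from compound 1 to compound 3 (1.08 log units; beyond the scatter) for 2-bromophenyl in place of 3-chlorophenyl. Compound 3 also inhibits more weakly than compound 2, the weaker of the earlier pair, with an at least 2.2-fold higher number from compound 2 to compound 3 (0.34 log units; beyond the scatter). The reading for compound 3 is a limit, not a number: the limit of > 150000 nM in this assay, at which 1 of the 3 values shown sits.

Both the halogen and its place on the ring change in this step, so their contributions cannot be told apart. From the compounds shown here alone, a 3-bromophenyl group on the same nitrogen would separate them, while the effect of an amine or a carboxylic acid on that ring remains open.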